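Lengthening the 2-hydroxyethyl group of compound 2

The source may hold more compounds than are shown below. What is called first, only, known or untested is meant among the compounds shown, and "the series" means these compounds.

Of the compounds shown here, two sharing one core have been measured in an ADME assay on RAW264.7 cells (Mus musculus) for cytotoxicity, read by MTT assay, with a stated time of 24 h; a higher number here means that more compound is tolerated, a lower number that less compound is tolerated. Compound 1 (`CC/C=C\C[C@H]1C(=O)C=C[C@H]1CC(=O)Oc1ccc(O)cc1`) gives 49 uM, and compound 2 (`CC/C=C\C[C@H]1C(=O)C=C[C@H]1CC(=O)OCCO`) gives 161 uM, the higher of the two numbers. The next compound, compound 3 (`CC/C=C\C[C@H]1C(=O)C=C[C@H]1CC(=O)OCCOCCO`), departs from compound 2 by 2-hydroxyethyl in place of hydrogen on an oxygen on a saturated carbon. In words, 2-hydroxyethyl stands in place of hydrogen on an oxygen on a saturated carbon, which turns 2-hydroxyethyl into 2-(2-hydroxyethoxy)ethyl.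

Going by the values given here, only one measured step bears on this change: a 3.3-fold higher number from compound 1 to compound 2 (0.52 log units; beyond the scatter), a modest move beyond the scatter. There, 2-hydroxyethyl replaced 4-hydroxyphenyl on an oxygen next to a carbonyl group. That exchange swapped one whole group for another, whereas the new change extends a group already present, so it is only a loose guide. Among the compounds with values here, no measured step extends such a chain. A small further rise in this assay is the likeliest direction, but nothing beyond the scatter is expected. The expected step is a 1.2-fold higher number from compound 2 to compound 3 (0.07 log units; within the scatter). For compound 3 the estimate is 190 uM, with an expected range of 95 uM to 380 uM.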

Compound 3, half-maximal toxic concentration: 166 uM
The estimate for compound 3 lay 1.1-fold (0.06 log units) above the measured number, and the stated range covers the measured number.
By their numbers in this assay, from the lowest: compound 1; then compounds 2 and 3 (each within the scatter of the next).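

Extending the chain on the oxygen on a saturated carbon gives a 1.0-fold higher number from compound 2 to compound 3 (0.01 log units; within the scatter) in this assay, so 2-hydroxyethyl and 2-(2-hydroxyethoxy)ethyl cannot be told apart here, and this position accepts the added 2-hydroxyethyl without a readable shift. The comparison with the aromatic compound holds as well: replacing 4-hydroxyphenyl with the longer group gives a 3.4-fold higher number from compound 1 to compound 3 (0.53 log units; beyond the scatter), a step much like the earlier 3.3-fold higher number from compound 1 to compound 2 (0.52 log units; beyond the scatter), so compounds 2 and 3 both stand beyond the scatter from compound 1. Nothing among the data available offers an explanation for either the flat step or the gap to compound 1.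

As far as these compounds go, with only these three compounds, it remains open whether a longer chain of the same kind would also leave the number within the scatter of compound 3, or whether the flat step holds only for this single extension. It is equally open how an amine or a carboxylic acid would fare in place of the terminal hydroxy group of 2-(2-hydroxyethoxy)ethyl, since every group shown here carries a hydroxy group.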